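A few compounds are considered here, and "the series" means these few. Any claim that something is new, unique, unknown or untested is made for them only; others in the source may bear on it.

Measured compounds in a functional assay on PANC-1 cells (Homo sapiens) for inhibition, read by MTT assay, with a stated time of 24 h, tested at 10 uM; on this read-out higher numbers stand for more inhibition at the one concentration tested (going by the name of the read-out) and lower numbers for less inhibition:
- compound 1, `CC(C)=CCC/C(C)=C/CC1Cc2c(OCCCNC(=O)c3ccco3)cc(=O)n(CCCO)c2CC1(C)C`: 2.8%
- compound 2, `CC(C)=CCC/C(C)=C/CC1Cc2c(OCCCNC(=O)c3cccs3)cc(=O)n(CCCO)c2CC1(C)C`: 11.5%
- compound 3, `CC(C)=CCC/C(C)=C/CC1Cc2c(OC(=O)Nc3ccc(F)cc3)cc(=O)n(CCCO)c2CC1(C)C`: 6.2%

All three numbers sit close together. Compound 3 has the second highest of the three, but its neighbours are within the scatter on both sides: a number 3.4 percentage points higher from compound 1 to compound 3 (within the scatter) and a number 5.3 percentage points lower from compound 2 to compound 3 (within the scatter). The remaining pair is likewise flat, a number 8.7 percentage points higher from compound 1 to compound 2 (within the scatter). Nothing in this set of three has yet moved the read-out beyond what repeated measurements would show.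

Compound 4, `CC(C)=CCC/C(C)=C/CC1Cc2c(OC(=O)Nc3ccc(F)c(Cl)c3)cc(=O)n(CCCO)c2CC1(C)C`, differs from compound 3 by chloro in place of hydrogen on an aromatic carbon. Among the compounds with values here, none of the measured steps touches this ring; the two steps that end at compound 3 exchange the whole group on the aromatic-ring oxygen and still stay within the scatter. There is therefore no measured basis for expecting a change larger than the scatter from a single chloro on the six-membered aromatic ring, and the expected step is a number 0.8 percentage points higher from compound 3 to compound 4 (within the scatter). The estimate for compound 4 is 7%, with a range from -3% to 18%.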

Compound 4, a percentage reported as inhibition, at one concentration (the size of the read-out at that concentration, not a potency): 0%
Estimate against measurement, compound 4: 7 percentage points above, and the stated range covers the measured number.
By their numbers in this assay, from the lowest: compounds 4, 1, 3 and 2 (each within the scatter of the next, the first and the last beyond it).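

In this assay, chloro in place of hydrogen, ortho to a fluoro group, is the only change at this position among the compounds shown, and a number 6.2 percentage points lower from compound 3 to compound 4 (within the scatter) leaves 4-fluorophenyl and 3-chloro-4-fluorophenyl indistinguishable on this read-out. Within the data shown here, the (3-chloro-4-fluorophenyl)carbamoyl group on the aromatic-ring oxygen gives the first step beyond the scatter, a number 11.5 percentage points lower from compound 2 to compound 4 (beyond the scatter), a modest one against the thiophen-2-yl side chain, whereas against the furan-2-yl side chain a number 2.8 percentage points lower from compound 1 to compound 4 (within the scatter) shows no separation. No available evidence bears on either result.

Open, going by these compounds, is whether a larger group on this aromatic carbon, such as a methoxy group, an amine or a carboxylic acid, would move the read-out beyond the scatter. Also open, on these data alone, is whether chloro behaves the same way on a ring without the fluoro group.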